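The source may report more compounds than this note shows. Statements on the series, on what has been measured and on what is new or still open speak of the compounds shown alone.

In a functional assay on HeLa cells (Homo sapiens) for cytotoxicity, read by colorimetric assay and neutral red uptake, with a stated time of 72 h (on this read-out higher numbers stand for weaker inhibition and lower numbers for stronger inhibition), compound 1 `CO[C@@H](C(=O)N[C@H]1CC[C@@H](O)CNC1=O)[C@H](O)[C@@H](O)[C@H](O)/C=C/C(C)(C)C` gives only a limit of the assay, > 150000 nM. Compound 2 `CO[C@@H](C(=O)N[C@@H]1CCCCNC1=O)[C@@H]1OC(C)(C)O[C@H](/C=C/C(C)(C)C)[C@@H]1O`, examined in this assay, likewise returns a limit, > 150000 nM. Among the compounds with values here, both results therefore rest at the limit of > 150000 nM in this assay, at which 2 of the 2 values shown sit, so compound 1 stands at the edge of what this assay can report rather than at a number, and no step between measured compounds can be sized from these data. Compound 3 `CO[C@@H](C(=O)N[C@@H]1CC[C@@H](O)CNC1=O)[C@H](O)[C@@H](O)[C@H](O)/C=C/C(C)(C)C` departs from compound 1 in a single respect: the two compounds have the same atoms and bonds and differ only in configuration as drawn: 1 of 7 stereo elements differ; a stereocentre at a saturated ring carbon is drawn S in compound 1 and R in compound 3. With only limits in hand, nothing measured indicates that this change of configuration alone would move the read-out in either direction. The expected step is a step that the limit leaves unreadable from compound 1 to compound 3, which amounts to none beyond the scatter of this assay. Compound 3 is accordingly expected to give about 200000 nM in this assay, with a range from 50000 nM to 600000 nM, and most likely to be reported once more only as a limit.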

Compound 3, half-maximal inhibitory concentration: 15400 nM
Compound 3: the middle estimate sits 13-fold (1.11 log units) above what was measured; the measured number lies below the stated range.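

Within the data shown here, changing one saturated ring carbon from S to R is the first change here whose effect can be read, and in this assay it gives an at least 9.7-fold lower number from compound 1 to compound 3 (0.98 log units; beyond the scatter). This shows that the configuration at this single position can separate a compound that returns a number from one that stays at a limit, which compounds 1 and 2 could not show on their own. The size of the step is only a lower bound, since the value for compound 1 is a limit and not a number, and the assignment of the step to this stereocentre rests on the fact that nothing else separates the pair: the fact that compounds 1 and 3 differ only in the configuration as drawn.

Compound 2 differs from the others in more than one place, so no step can be read for it, and the compounds shown do not tell whether its changes would matter with the R configuration in place. They also leave open whether the number for compound 3 would hold with an amine in place of the ring hydroxyl, or with a longer chain in place of the tert-butyl end of the alkene.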